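The source may report more compounds than this note shows. Statements on the series, on what has been measured and on what is new or still open speak of the compounds shown alone.

Measured so far:
compound 1, `COc1nc2ccc(Br)cc2cc1C(c1ccccc1)n1cc(-c2ccccc2)nn1`, 13.7% in an ADME assay on SK-OV-3 cells (Homo sapiens) for cytotoxicity, read by sulforhodamine B assay, with a stated time of 48 h, tested at 10 uM; on this read-out higher numbers stand for more inhibition at the one concentration tested (going by the name of the read-out) and lower numbers for less inhibition
compound 2, `COc1nc2ccc(Br)cc2cc1C(c1ccccc1)n1cc(-c2ccccc2F)nn1`, 7.33%

In this assay compound 2 gives 7.33%. Within the data shown here, its only neighbour is compound 1, and the step of a number 6.4 percentage points lower from compound 1 to compound 2 (within the scatter) lies within the scatter, so the two numbers stand level and neither can be called the higher or the lower. Compound 3, `CCOC(=O)c1cn(C(c2ccccc2)c2cc3cc(Br)ccc3nc2OC)nn1`, is not yet measured. It differs from compound 2 in one place: ethoxycarbonyl in place of 2-fluorophenyl on an aromatic carbon. Among the measured compounds shown here, the single measured step, a number 6.4 percentage points lower from compound 1 to compound 2 (within the scatter), concerns a fluoro in place of hydrogen on an aromatic carbon, a much smaller exchange, and it gives no direct guide to the present change. Both measured numbers are low, and nothing among them points to a move beyond the scatter, so compound 3 is expected to stay near them, with an expected step of a number 2.7 percentage points higher from compound 2 to compound 3 (within the scatter). The value of compound 3 in this assay is estimated at 10%, within -5% to 30%.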

Compound 3, a percentage reported as inhibition, at one concentration (the size of the read-out at that concentration, not a potency): 2.01%
Estimate against measurement, compound 3: 8 percentage points above; the range from low to high includes it.
By their numbers in this assay, from the lowest: compounds 3, 2 and 1 (each within the scatter of the next, the first and the last beyond it).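

Among these compounds, with ethoxycarbonyl in place of phenyl on this aromatic carbon, the five-membered ring carries a group with no ring for the first time, and this assay records a number 11.7 percentage points lower from compound 1 to compound 3 (beyond the scatter), the first modest step that stands clear of the scatter. The exchange for 2-fluorophenyl gives a number 5.3 percentage points lower from compound 2 to compound 3 (within the scatter), so the ringless group separates only from the unsubstituted phenyl and not from its fluoro analogue. Nothing measured here explains either step.

The compounds shown leave open whether an amine or a carboxylic acid in place of ethoxycarbonyl on this carbon, or a longer chain in place of its ethyl part, would shift the number beyond the scatter. They also leave open whether any group here can raise the inhibition well above that of compound 1.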